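Indole in place of benzimidazole on a diphenylmethylpiperazine chain

A few compounds are considered here, and "the series" means these few. Any claim that something is new, unique, unknown or untested is made for them only; others in the source may bear on it.

Measured so far:
compound 1, `O=c1[nH]c2ccccc2n1C/C=C/CN1CCN(C(c2ccccc2)c2ccccc2)CC1`, > 10000 nM
compound 2, `Cc1cc2ncn(CCCCN3CCN(C(c4ccccc4)c4ccccc4)CC3)c2cc1C`, 770 nM
compound 3, `COC(=O)c1cccc2ccn(CCCCN3CCN(C(c4ccccc4)c4ccccc4)CC3)c12`, > 10000 nM

All three compounds share a diphenylmethylpiperazine joined through a four-carbon chain to an aromatic ring system, and all were tested in an assay on RPMI-8226 cells for antagonist activity at P2X purinoceptor 7 (Homo sapiens), read by calcium flux; on this read-out lower numbers stand for stronger inhibition and higher numbers for weaker inhibition. Compound 1 reached only the limit of this assay, > 10000 nM, which is not a number. Compound 3 likewise stopped at the limit, > 10000 nM. For the measured compounds named here, compound 2 is the one compound with a measured number, 770 nM; the other two values are the limit of > 10000 nM in this assay, at which 2 of the 3 values shown sit.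

Compound 4, `Fc1ccc2c(ccn2CCCCN2CCN(C(c3ccccc3)c3ccccc3)CC2)c1`, has not yet been measured in this assay. It differs from compound 2 in one place: 5-fluoro-1H-indol-1-yl in place of 5,6-dimethyl-1H-benzimidazol-1-yl on a saturated chain carbon, four bonds along the chain from an amine nitrogen in a ring. Going by the values given here, no measured pair differs in a single place, so the size of this step cannot be read from the data. Since two of three ring systems tried so far gave only a limit, a step toward weaker inhibition, beyond the scatter, seems the more likely outcome; compound 4 is therefore expected at 2500 nM, within 600 nM to 10000 nM, a step of a 3.2-fold higher number from compound 2 to compound 4 (0.51 log units; beyond the scatter).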

Compound 4, half-maximal inhibitory concentration: 120 nM
Compound 4: middle estimate off by 21-fold (1.32 log units), on the high side; the whole stated range lies above it.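

In this assay, replacing 5,6-dimethyl-1H-benzimidazol-1-yl with 5-fluoro-1H-indol-1-yl on a saturated chain carbon, four bonds along the chain from an amine nitrogen in a ring, gives a 6.4-fold lower number from compound 2 to compound 4 (0.81 log units; beyond the scatter). For the compounds shown here, this is the first readable step at this place, and it shows that the 5,6-dimethyl-1H-benzimidazol-1-yl group is not needed for a measured number. Compound 1 and compound 3 still give no number to compare: the limit of > 10000 nM in this assay, at which 2 of the 4 values shown sit.

The swap changes the ring nitrogens, the two methyl groups and the fluorine all at once, so the step cannot be divided among them. A 5,6-dimethyl-1H-indol-1-yl group would help to separate these parts, while a 5-chloro-1H-indol-1-yl group would test whether fluorine itself matters.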